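Swapping atoms within the cyano ring group of compound 3

The source may hold more compounds than are shown below. What is called first, only, known or untested is meant among the compounds shown, and "the series" means these compounds.

Compound 1 `COC(=O)C1=C(C)N=C(C)/C(=C(/O)OC)C1c1cccc(OCc2c(C(N)=O)no[n+]2[O-])c1` gives 1200 nM
Compound 2 `COC(=O)C1=C(C)N=C(C)/C(=C(/O)OC)C1c1cccc(OCc2nonc2C#N)c1` gives 310 nM
Compound 3 `COC(=O)C1=C(C)N=C(C)/C(=C(/O)OC)C1c1cccc(OCc2c(C#N)no[n+]2[O-])c1` gives 11 nM

In a functional assay (aorta) with Rattus norvegicus as the target, in the presence of a further agent that is not named here (a lower number here means that less compound is needed, a higher number that more compound is needed for the effect), compound 3 has the lowest of the three numbers. Compound 4 `COC(=O)C1=C(C)N=C(C)/C(=C(/O)OC)C1c1cccc(OCc2no[n+]([O-])c2C#N)c1` has the same atoms, joined differently: a group of 8 heavy atoms (3 carbon, 3 nitrogen, 2 oxygen; one five-membered aromatic ring with 3 hetero atoms) in place of a group of 8 heavy atoms (3 carbon, 3 nitrogen, 2 oxygen; one five-membered aromatic ring with 3 hetero atoms), on a saturated chain carbon bound to an oxygen on an aromatic ring. Going by the values given here, no measured step makes this exact swap, so the guidance is indirect. Two changes to this group gave large steps, a 28-fold lower number from compound 2 to compound 3 (1.45 log units; beyond the scatter) and a 110-fold lower number from compound 1 to compound 3 (2.04 log units; beyond the scatter), and a third gave a modest one, a 3.9-fold lower number from compound 1 to compound 2 (0.59 log units; beyond the scatter). With compound 3 already lowest and this group so sensitive, a rise is expected, estimated as a 5.5-fold higher number from compound 3 to compound 4 (0.74 log units; beyond the scatter). Compound 4 is expected near 60 nM, with an estimated range of 15 nM to 300 nM.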

Compound 4, half-maximal effective concentration: 3.3 nM
For compound 4 the middle estimate is 18-fold (1.26 log units) above the measured one; the measured number lies below the stated range.
By their numbers in this assay, from the lowest: compound 4; then compound 3; then compound 2; then compound 1.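

Within this assay the same atoms, joined differently in the ring on the saturated chain carbon, still shift the result (a 3.3-fold lower number from compound 3 to compound 4 (0.52 log units; beyond the scatter)), so the arrangement of this group matters as well as its atoms. Compound 4 also has the lowest number of the four, with larger steps from the other two compounds (a 94-fold lower number from compound 2 to compound 4 (1.97 log units; beyond the scatter); a 360-fold lower number from compound 1 to compound 4 (2.56 log units; beyond the scatter)). No measurement here explains why this arrangement needs less compound. As far as these compounds go, whether an amine or a carboxylic acid in place of the nitrile on this ring would keep the number this low remains open.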